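The source may hold more compounds than are shown below. What is called first, only, known or untested is meant among the compounds shown, and "the series" means these compounds.

Measured compounds in the series:

compound 1 `Cn1c(=O)c(=O)n(C2CCCC2)c2nc(N/N=C/c3cccs3)ncc21`: > 100000 nM
compound 2 `Cn1c(=O)c(=O)n(C2CCCC2)c2nc(N/N=C/c3cc(C(F)(F)F)cc(C(F)(F)F)c3)ncc21`: 3230 nM

Compound 1 carries thiophen-2-yl on the carbon with a double bond to nitrogen. In a functional assay on A549 cells (Homo sapiens) for antiproliferative activity, read by MTT assay (on this read-out higher numbers stand for weaker inhibition and lower numbers for stronger inhibition), compound 1 gives > 100000 nM, which is a limit of the assay and not a measured number (the limit of > 100000 nM in this assay, at which 1 of the 2 values shown sits). Compound 2 carries a six-membered aromatic ring of carbon only at the same place and gives 3230 nM in this assay, a numerical value rather than a limit.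

Compound 3 `Cn1c(=O)c(=O)n(C2CCCC2)c2nc(N/N=C/c3ccc(F)cc3F)ncc21` is not yet measured. It differs from compound 1 in one place: 2,4-difluorophenyl in place of thiophen-2-yl on a carbon with a double bond to nitrogen. With no measured step of this kind in hand, the expectation rests on the two values shown: a step from compound 1 to compound 3 of an at least 3.3-fold lower number from compound 1 to compound 3 (0.52 log units; beyond the scatter) toward stronger inhibition, beyond the usual scatter, is expected. Compound 3 is estimated at 30000 nM in this assay, within 5000 nM to 100000 nM, with a real chance that only a limit is again reported.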

Compound 3, half-maximal inhibitory concentration: 18300 nM
Compound 3: middle estimate off by 1.6-fold (0.21 log units), on the high side, within the range that was stated.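

In this assay, 2,4-difluorophenyl in place of thiophen-2-yl on a carbon with a double bond to nitrogen gives an at least 5.4-fold lower number from compound 1 to compound 3 (0.73 log units; beyond the scatter), so this position responds to a change of ring. The value for compound 1 is a limit of the assay and not a number, so the step has a floor and no known size: the limit of > 100000 nM in this assay, at which 1 of the 3 values shown sits. With compound 3 at 18300 nM, a second six-membered aromatic ring of carbon only gives a numerical value at this place, as compound 2 does at 3230 nM.

The compounds shown leave open whether the ring itself or its fluorine atoms carry the step, and what an unsubstituted phenyl or a phenyl bearing an amine would give here. Also open, as far as these compounds go, is whether a longer alkyl chain on this carbon keeps any activity in this assay.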